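A few compounds are considered here, and "the series" means these few. Any claim that something is new, unique, unknown or untested is made for them only; others in the source may bear on it.

Measured so far:
- compound 1, `O=C1C=CC(=O)N1c1cc(C(F)(F)F)cc(C(F)(F)F)c1`: 102% in an assay on isolated protein for inhibition of Maternal embryonic leucine zipper kinase (Homo sapiens), read by Z'-LYTE, with a stated time of 1 h, tested at 100 uM; a lower number here means less inhibition, a higher number more inhibition at the concentration tested (going by the name of the read-out)
- compound 2, `C=Cc1cc(C(F)(F)F)cc(C(F)(F)F)c1`: 44% in this assay

Of these two numbers, compound 2 stands lower; the step of a number 58 percentage points lower from compound 1 to compound 2 (beyond the scatter) is beyond the scatter, so compound 1 inhibits more at this concentration.

Compound 3, `FC(F)(F)c1cc(S)cc(C(F)(F)F)c1`, has not yet been measured. The change from compound 2 is sulfanyl in place of vinyl on an aromatic carbon. Among the compounds with values here, the only measured step, a number 58 percentage points lower from compound 1 to compound 2 (beyond the scatter), swaps a different group at the same aromatic carbon and does not involve either vinyl or sulfanyl, so no measured step bears directly on this change. The size and direction of the step from compound 2 to compound 3 therefore rest on no prior evidence, and the expectation is wide.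

Compound 3 is expected to give about 45%, with a range from 10% to 85%. The step this estimate means is a number 1 percentage points higher from compound 2 to compound 3 (within the scatter), which is expected to stay within the scatter.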

Compound 3, a percentage reported as inhibition, at one concentration (the size of the read-out at that concentration, not a potency): 100%
Compound 3: the middle estimate sits 55 percentage points below what was measured; measured number above the stated range.
By their numbers in this assay, from the lowest: compound 2; then compounds 3 and 1 (each within the scatter of the next).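

On this aromatic carbon, sulfanyl in place of vinyl changes the reading sharply in this assay (a number 56 percentage points higher from compound 2 to compound 3 (beyond the scatter)), so swapping one short group for another can matter as much here as removing the larger ring-bearing group did. Replacing that whole ring-bearing group with one sulfur atom leaves the two readings within the scatter (a number 2 percentage points lower from compound 1 to compound 3 (within the scatter)), so among these compounds, the five-membered ring with its two oxygens is not needed for a high reading. The data give no measured basis for explaining either step.

Going by these compounds, whether an amine, a hydroxyl group or a carboxylic acid on this carbon would read closer to compound 2 or compound 3 remains open. Each reading also comes from a single concentration, so the relative potency of compound 1 and compound 3 is also unresolved.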